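The source may report more compounds than this note shows. Statements on the series, on what has been measured and on what is new or still open speak of the compounds shown alone.

Compound 1 `O=C(c1cc(=O)[nH]c2cc(Br)ccc12)N1CCCCC1`: > 20000 nM (a limit of the assay, not a number)
Compound 2 `O=C(Nc1ccc(OC(F)(F)F)cc1)c1cc(=O)[nH]c2cc(Br)ccc12`: > 20000 nM (a limit of the assay, not a number)
Compound 3 `O=C(Nc1cccc(F)c1)c1cc(=O)[nH]c2cc(-c3ccc(F)cc3)ccc12`: 10300 nM

All three compounds were tested in a functional assay on KYSE-410 cells (Homo sapiens) for antiproliferative activity, read by MTT assay, with a stated time of 72 h; a higher number here means a weaker inhibitor, a lower number a stronger inhibitor. For compound 1 and compound 2 the result is a limit: the limit of > 20000 nM in this assay, at which 2 of the 3 values shown sit. Going by the values given here, compound 3 gives 10300 nM, the only actual number in this small set.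

The next compound to be measured is compound 4 `O=C(Nc1cccc(F)c1)c1cc(=O)[nH]c2cc(-c3cccc(F)c3)ccc12`. It has the same atoms as compound 3, joined differently: 3-fluorophenyl in place of 4-fluorophenyl on an aromatic carbon. In words, 3-fluorophenyl stands in place of 4-fluorophenyl on an aromatic carbon, and the rest of the structure stays the same.

Among the compounds with values here, no two measured compounds differ in just one place, leaving no direct measure of how large such a step tends to be. Starting from compound 3 at 10300 nM, no change beyond the usual scatter is expected, and no particular direction is favoured. The expected result is a 1.1-fold higher number from compound 3 to compound 4 (0.03 log units; within the scatter). Compound 4 is estimated at 11000 nM, with an expected range from 5500 nM to 20000 nM.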

Compound 4, half-maximal inhibitory concentration: 10900 nM
Compound 4: middle estimate off by 1.0-fold (0.00 log units), on the high side, and the stated range covers the measured number.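

In this assay, 3-fluorophenyl in place of 4-fluorophenyl gives a 1.1-fold higher number from compound 3 to compound 4 (0.02 log units; within the scatter). Going by these compounds alone, this is the first measured step in this small set that changes one place only, and it shows that these two placements of the fluorine on the phenyl ring cannot be told apart in this assay, even though the structure has been rearranged. Compound 1 and compound 2 remain at a limit of the assay and supply no number to set against this step: the limit of > 20000 nM in this assay, at which 2 of the 4 values shown sit.

The step therefore says something about where the fluorine sits, but nothing about whether the fluorine matters at all, and a plain phenyl ring would be needed to address that. As far as these compounds go, it also remains open whether a different group on this phenyl ring, such as a methoxy group, an amine or a carboxylic acid, would shift the number beyond the usual scatter, or whether the ring tolerates such changes as quietly as it tolerates this one.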